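From propyl to butyl: working notes on the series

The compounds below may be only part of what the source reports. "The series", "measured", "known", "first", "only" and "open" are said of these compounds alone.

Compound 1 `CCc1cnc(OCC(C)(C)O)c(-c2ccc(S(C)(=O)=O)cc2)c1`: 1.15 h
Compound 2 `CCCOc1nc(OCC(C)(C)O)c(-c2ccc(S(C)(=O)=O)cc2)cc1CO`: > 3.06 h

Both readings come from an ADME assay on microsomes from liver (Homo sapiens) for metabolic stability; on this read-out lower numbers stand for a shorter-lived compound and higher numbers for a longer-lived compound. Compound 2 stands at the limit of > 3.06 h in this assay, at which 1 of the 2 values shown sits. For compound 2 the reading > 3.06 h is a limit and not a number. Within the data shown here, compound 1, at 1.15 h, holds the only exact value so far.

Compound 3 `CCCCOc1nc(OCC(C)(C)O)c(-c2ccc(S(C)(=O)=O)cc2)cc1CO` differs from compound 2 by methyl in place of hydrogen on a saturated chain carbon, three bonds along the chain from an oxygen on an aromatic ring, so that propyl becomes butyl. Among the measured compounds shown here, no measured pair isolates this change. No step beyond the usual scatter is expected in this assay, and any drift is more likely toward a shorter half-life. The estimated at least 1.0-fold lower number from compound 2 to compound 3 (0.00 log units; that floor lies within the scatter) is expected to stay within that scatter. Compound 3 is expected at 3 h, with an estimated range of 1.5 h to 6 h.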

Compound 3, half-life: 0.463 h
Compound 3: the middle estimate sits 6.5-fold (0.81 log units) above what was measured; measured number below the stated range.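

At this position, on a saturated chain carbon three bonds along the chain from an oxygen on an aromatic ring, a single added methyl is not a silent change: in this assay, propyl to butyl gives an at least 6.6-fold lower number from compound 2 to compound 3 (0.82 log units; beyond the scatter). Among these compounds, this is the first pair that isolates a change in this chain, and it shows that the half-life can respond to one added carbon there. For compound 2 the reading is a limit and not a number, so the step can be read only as a floor: the limit of > 3.06 h in this assay, at which 1 of the 3 values shown sits.

As far as these compounds go, whether a longer chain such as pentyl would continue in the same direction in this assay remains open, as does the effect of a branched chain such as isobutyl. The compounds shown also give no account of what lies behind the step.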